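Silyl to amide exchange on the shared core

The compounds below may be only part of what the source reports. "The series", "measured", "known", "first", "only" and "open" are said of these compounds alone.

Compound 2 `CC[Si](CC)(CC)C/C1=C/C[C@](C)(CCC=C(C)C)/C=C/[C@@H](OC(=O)C=C(C)C)[C@](C)(O)/C=C/C1=O` gives 3150 nM in a functional assay on MCF7 cells (Homo sapiens) for antiproliferative activity, read by MTT assay, with a stated time of 48 h (on this read-out higher numbers stand for weaker inhibition and lower numbers for stronger inhibition), the highest of the two numbers measured; compound 1 `CC(C)=CCC[C@]1(C)/C=C/[C@@H](OC(=O)C=C(C)C)[C@](C)(O)/C=C/C(=O)/C(CN(C(C)C)C(C)C)=C\C1` gives 780 nM. Compound 3 `CC(C)=CCC[C@]1(C)/C=C/[C@@H](OC(=O)C=C(C)C)[C@](C)(O)/C=C/C(=O)/C(C(=O)N(C(C)C)C(C)C)=C\C1` differs from compound 2 by a group of 9 heavy atoms (7 carbon, 1 nitrogen, 1 oxygen; no ring) in place of a group of 8 heavy atoms (7 carbon, 1 silicon; no ring), on a double-bonded ring carbon. Among the measured compounds shown here, the one measured step that bears on this, a 4.0-fold higher number from compound 1 to compound 2 (0.61 log units; beyond the scatter), exchanged a nitrogen-bearing group for a silicon-bearing one, so restoring a nitrogen-bearing group is expected to lower the number, although no measured compound carries a diisopropylcarbamoyl group and the amide is untested. A step of a 3.2-fold lower number from compound 2 to compound 3 (0.50 log units; beyond the scatter) is therefore expected. Compound 3 is estimated at 1000 nM, within 300 nM to 3500 nM.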

Compound 3, half-maximal inhibitory concentration: 17200 nM
The estimate for compound 3 lay 17-fold (1.24 log units) below the measured number; measured number above the stated range.
By their numbers in this assay, from the lowest: compound 1; then compound 2; then compound 3.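

In this assay, a nitrogen at this position does not by itself keep the number low: diisopropylcarbamoyl in place of (diisopropylamino)methyl gives a 22-fold higher number from compound 1 to compound 3 (1.34 log units; beyond the scatter) and the same group set against the silicon-bearing group gives a 5.5-fold higher number from compound 2 to compound 3 (0.74 log units; beyond the scatter). The diisopropyl substitution on nitrogen is common to compound 1 and compound 3, so the read-out follows the carbon joining that nitrogen to the ring, methylene versus carbonyl. Nothing available explains the rise.

As far as these compounds go, whether a smaller amine such as dimethylamino on the same methylene keeps the number of compound 1 remains open. So does whether a carboxylic acid or methyl ester on this ring carbon tracks compound 3.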